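A few compounds are considered here, and "the series" means these few. Any claim that something is new, unique, unknown or untested is made for them only; others in the source may bear on it.

The series rests on a shared core carrying a benzyloxy group at each of two positions and an ester-bearing side chain. Compound 1 `O=C1C=C[C@@H](OCc2ccccc2)[C@@H]([C@@H](COC(=O)/C=C/c2ccccc2)OCc2ccccc2)O1`, whose side chain ends in a cinnamate ester, gives 9510 nM in a functional assay on HeLa cells (Homo sapiens) for antiproliferative activity, read by MTT assay, with a stated time of 6 days; a lower number here means a stronger inhibitor, a higher number a weaker inhibitor. Compound 2 `O=C1C=C[C@@H](OCc2ccccc2)[C@@H]([C@@H](COC(=O)/C=C/c2ccc(F)cc2)OCc2ccccc2)O1` carries the same ester with a fluorine on the aromatic ring; in this assay compound 2 gives 7310 nM. The one step measured so far, a 1.3-fold lower number from compound 1 to compound 2 (0.11 log units; within the scatter), is within the scatter, so on the numbers shown compound 2 stands at the lower of two values but is not separated from compound 1.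

Compound 3 `CC(=O)OC[C@@H](OCc1ccccc1)[C@H]1OC(=O)C=C[C@H]1OCc1ccccc1` is not yet measured. It differs from compound 2 by methyl in place of 2-(4-fluorophenyl)ethenyl on a carbonyl carbon; the ester is thus cut back to an acetate. For the measured compounds named here, no measured step bears on this change: the only step known alters a substituent on the aromatic ring, and its size, a 1.3-fold lower number from compound 1 to compound 2 (0.11 log units; within the scatter), says nothing about removing the whole 2-(4-fluorophenyl)ethenyl group. The account therefore expects for compound 3 a step of a 2.1-fold higher number from compound 2 to compound 3 (0.31 log units; beyond the scatter) toward a higher number, but with wide uncertainty. Compound 3 is estimated at 15000 nM, with a range from 5000 nM to 50000 nM.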

Compound 3, half-maximal inhibitory concentration: 5350 nM
The estimate for compound 3 lay 2.8-fold (0.45 log units) above the measured number; the range from low to high includes it.
By their numbers in this assay, from the lowest: compounds 3, 2 and 1 (each within the scatter of the next).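

Replacing the whole 2-(4-fluorophenyl)ethenyl group on the carbonyl carbon with methyl in this assay gives a 1.4-fold lower number from compound 2 to compound 3 (0.14 log units; within the scatter). The matching change in the compound without fluorine, methyl in place of 2-phenylethenyl, gives a 1.8-fold lower number from compound 1 to compound 3 (0.25 log units; within the scatter) and so reads the same way. The earlier step touched only one substituent on the aromatic ring, whereas these two show that, among the three compounds, an acetate at this position is not separated from either cinnamate-type ester, even though the change takes away an aromatic ring and a double bond outside it; nothing available on these compounds accounts for this result.

What the compounds leave open is whether any group at this position would move the number beyond the scatter, for instance a free hydroxyl, an amine or a longer chain such as butanoyl in place of the acetyl. As far as these compounds go, the two benzyloxy groups on the shared core stay the same in all three compounds, so their part in the numbers also remains open.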